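This account rests on a few compounds, and the source may have more. Where it says the series, first, only, none or still open, it means among the compounds named here.

Working notes on the series.

Compound 1 `COc1cc(NC(C)CCCNC(=O)NNC(=O)Nc2cccc(F)c2)c2ncccc2c1` gives 150 nM in a functional assay on MCF7 cells (Homo sapiens) for inhibition, read by MTT assay, with a stated time of 72 h; a higher number here means a weaker inhibitor, a lower number a stronger inhibitor. Compound 2 `COc1cc(NC(C)CCCNC(=O)Nc2ccc(F)cc2)c2ncccc2c1` gives 26000 nM, and compound 3 `COc1cc(NC(C)CCCNC(=O)NNC(=O)Nc2ccc(O)cc2)c2ncccc2c1` gives 2600 nM. Compound 3 stands second highest of the three numbers: the step of a 17-fold higher number from compound 1 to compound 3 (1.24 log units; beyond the scatter) sets it well apart from compound 1, and the step of a 10-fold lower number from compound 2 to compound 3 (1.00 log units; beyond the scatter) places it a modest distance from compound 2.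

Compound 4 `COc1cc(NC(C)CCCNC(=O)NNC(=O)Nc2ccc(C(F)(F)F)cc2)c2ncccc2c1` is not yet measured. It differs from compound 3 in one place, (trifluoromethyl in place of hydroxy on an aromatic carbon), the new group sitting on an aromatic carbon of a six-membered aromatic ring of carbon only, para to a large group.

The step of a 17-fold higher number from compound 1 to compound 3 (1.24 log units; beyond the scatter) is the one that bears directly on this, as it too exchanges only the group on the terminal aryl ring and was large. The step of a 170-fold higher number from compound 1 to compound 2 (2.24 log units; beyond the scatter) changes the linker as well and is less informative. Given that a fluorine-bearing ring in compound 1 gave the lowest number shown, the expectation for compound 4 is a lower number than compound 3, on the order of a 3.3-fold lower number from compound 3 to compound 4 (0.51 log units; beyond the scatter). Compound 4 is estimated at 800 nM, within a range of 200 nM to 3500 nM.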

Compound 4, half-maximal inhibitory concentration: 100 nM
Compound 4: the middle estimate sits 8.0-fold (0.90 log units) above what was measured, outside the stated range (below it).
By their numbers in this assay, from the lowest: compounds 4 and 1 (each within the scatter of the next); then compound 3; then compound 2.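

At this place, on an aromatic carbon para to a large group, trifluoromethyl in place of hydroxy gives a large step in this assay (a 26-fold lower number from compound 3 to compound 4 (1.41 log units; beyond the scatter)), so the distance of compound 3 from compound 1 now points to the hydroxy group itself and not to any change of the group on this ring. With 4-(trifluoromethyl)phenyl in place of 3-fluorophenyl, the two fluorine-bearing compounds cannot be told apart (a 1.5-fold lower number from compound 1 to compound 4 (0.18 log units; within the scatter)), so two different fluorine-bearing rings reach the same level on this linker. Nothing shown gives a measured reason for the size of the hydroxy to trifluoromethyl step.

On these data alone, whether an amine, a carboxylic acid or a methoxy group at this place would fall with compound 3 or with compound 4 remains open. Compound 1 and compound 4 differ in both the group and its place on the ring, so the effect of each alone also remains unresolved.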